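The source may hold more compounds than are shown below. What is called first, only, known or untested is meant among the compounds shown, and "the series" means these compounds.

Three measured compounds share one core and differ only in the group on one aromatic carbon. Compound 1 `COc1ccc(-c2nc(CNc3ccc(C(=O)NO)cc3)n(-c3ccccc3)n2)cc1` carries 4-methoxyphenyl there, and in an assay on Sf9 cells for inhibition of protein deacetylase HDAC6 (Homo sapiens), read by fluorescence, with a stated time of 40 min, tested at 100 nM (a higher number here means more inhibition at the concentration tested (going by the name of the read-out), a lower number less inhibition), compound 1 gives 77.6%. Compound 2 `Cc1ccc(-c2nc(CNc3ccc(C(=O)NO)cc3)n(-c3ccccc3)n2)s1` carries 5-methylthiophen-2-yl, and in this assay compound 2 gives 79.7%. Compound 3 `O=C(NO)c1ccc(NCc2nc(-c3ccccc3)nn2-c2ccccc2)cc1` carries plain phenyl, and in this assay compound 3 gives 72.6%. Compound 3 sits at the low end of the three numbers, yet every gap stays within the usual scatter: a number 5 percentage points lower from compound 1 to compound 3 (within the scatter), a number 7.1 percentage points lower from compound 2 to compound 3 (within the scatter), and between the other two a number 2.1 percentage points higher from compound 1 to compound 2 (within the scatter). On the numbers shown, the three are not separable.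

Compound 4 `Cc1cccc(-c2nc(CNc3ccc(C(=O)NO)cc3)n(-c3ccccc3)n2)c1` differs from compound 3 in one place: methyl in place of hydrogen on an aromatic carbon. Among the measured compounds shown here, two measured steps bear on this. Adding or removing methoxy on the six-membered aromatic ring of carbon only gave a number 5 percentage points lower from compound 1 to compound 3 (within the scatter), and exchanging the whole aryl group gave a number 7.1 percentage points lower from compound 2 to compound 3 (within the scatter); neither reached beyond the scatter. A single methyl entering the same ring is therefore expected to do no more, and the expected step is a number 1.4 percentage points higher from compound 3 to compound 4 (within the scatter). Compound 4 is estimated at 74%, with a range from 63% to 85%.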

Compound 4, a percentage reported as inhibition, at one concentration (the size of the read-out at that concentration, not a potency): 64.1%
Beside the measured number, compound 4's estimate is 9.9 percentage points above it; measured number inside the range.
By their numbers in this assay, from the lowest: compounds 4, 3, 1 and 2 (each within the scatter of the next, the first and the last beyond it).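

In this assay, methyl on the phenyl ring of compound 3 gives a step that stays within the scatter (a number 8.5 percentage points lower from compound 3 to compound 4 (within the scatter)), so this single added carbon cannot be read as a change by itself. Among the compounds shown here, compound 4 is nevertheless the first compound to separate from any other, with modest steps beyond the scatter against both the 5-methylthiophen-2-yl group (a number 15.6 percentage points lower from compound 2 to compound 4 (beyond the scatter)) and the 4-methoxyphenyl group (a number 13.5 percentage points lower from compound 1 to compound 4 (beyond the scatter)), whereas compound 3 separates from neither, so the aryl position is no longer fully flat across the set. Nothing among the available data accounts for this separation.

The compounds shown leave open whether methyl on another carbon of the ring would match 3-methylphenyl, and whether an amine or a carboxylic acid on this ring would move the number beyond the scatter from compound 3. With a read-out taken at a single concentration, they also leave open how far the separation of compound 4 from compound 1 and compound 2 would hold as a difference in potency.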